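Amine pKa across a secondary amine series

A few compounds are considered here, and "the series" means these few. Any claim that something is new, unique, unknown or untested is made for them only; others in the source may bear on it.

Measured so far:
compound 1 `CN(C)c1cccc(Oc2ccc3c(NCCCNCc4ccco4)ccnc3c2)c1`, 9.28
compound 2 `COc1ccc(F)cc1CNCCCNc1ccnc2cc(-c3cccc4ccccc34)ccc12`, 9.47

Compound 2 gives the higher of the two numbers in a physicochemical assay for acid dissociation, its nearest neighbour being compound 1, which sits within the usual scatter of it.

Compound 3 `c1coc(CNCCCNc2ccnc3cc(-c4cccc5ccccc45)ccc23)c1` is not yet measured. It differs from compound 2 in one place: furan-2-yl in place of 5-fluoro-2-methoxyphenyl on a saturated chain carbon bound to an amine nitrogen. For the measured compounds named here, no step between measured compounds covers this change. Compound 1 carries the same (furan-2-yl)methyl on its amine and gives 9.28 in this assay, so no step beyond the scatter is expected here.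

The estimate for compound 3 is 9.3, range 9 to 9.6, an expected step of a number 0.17 log units lower from compound 2 to compound 3 (within the scatter).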

Compound 3, acid dissociation constant: 9.47
Beside the measured number, compound 3's estimate is 0.17 log units below it; the measured number falls inside the stated range.
By their numbers in this assay, from the lowest: compounds 1, 2 and 3 (each within the scatter of the next).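

In this assay, for the compounds shown here, furan-2-yl in place of 5-fluoro-2-methoxyphenyl on a saturated chain carbon bound to an amine nitrogen gives no change at the digits printed from compound 2 to compound 3 (within the scatter), the first direct reading of a change at this position. Naphthalen-1-yl in place of 3-(dimethylamino)phenoxy on an aromatic carbon gives a number 0.19 log units higher from compound 1 to compound 3 (within the scatter), so neither single change moves the read-out beyond the scatter. No evidence on the origin of these results is available. Only aromatic rings appear on this chain carbon in the compounds shown. On these data alone, how cyclohexyl or a carboxylic acid there, or a longer chain, would read remains open.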